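Methoxy added to a dimethoxyphenyl arm on a quinoline-ether core

The compounds below may be only part of what the source reports. "The series", "measured", "known", "first", "only" and "open" are said of these compounds alone.

Compound 1 `COc1ccc(/C=C/C(=O)/C=C/c2cc3ccccc3nc2Cl)c(OC)c1` and compound 2 `COc1cc(OC)c(OC)cc1/C=C/C(=O)/C=C/c1cc2ccccc2nc1Cl` share one core, while compound 3 `COc1ccc(/C=C/C(=O)/C=C/c2cc3ccccc3nc2Oc2ccc(Br)cc2)cc1` and the unmeasured compound 4 `COc1ccc(/C=C/C(=O)/C=C/c2cc3ccccc3nc2Oc2ccc(Br)cc2)c(OC)c1` share another; the difference between the two cores is not broken down here. In a functional assay on HGC-27 cells (Homo sapiens) for cytotoxicity, read by MTT assay, with a stated time of 48 h (a higher number here means a weaker inhibitor, a lower number a stronger inhibitor), compound 1 reaches only the assay limit, > 10000 nM. Compound 2 gives 8730 nM in this assay. The change between them is methoxy in place of hydrogen on an aromatic carbon, and it yields an at least 1.1-fold lower number from compound 1 to compound 2 (0.05 log units; that floor lies within the scatter); the step is known only as a floor because the limit of > 10000 nM in this assay, at which 2 of the 3 values shown sit, caps what compound 1 can show. Compound 3 likewise sits at the assay limit, > 10000 nM, in this assay. The change to compound 4 is the same kind of change, (methoxy in place of hydrogen on an aromatic carbon), yet its surroundings differ: here the entering methoxy is ortho to a large group and meta to a methoxy group, whereas in compound 2 it is ortho to a methoxy group, meta to a large group and para to a methoxy group. Given that the one measured step is only a floor inside the scatter, the expected step of a number no higher from compound 3 to compound 4 (the limit leaves the size open) is small, and compound 4 is estimated at 10000 nM, between 4000 nM and 30000 nM, with a fair chance that only a limit is reported.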

Compound 4, half-maximal inhibitory concentration: > 10000 nM
Compound 4 was reported as a limit (the forecaster's own chance of this, stated with the estimate: 60%); the middle value sits exactly at the limit.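

In this assay compound 4 gives > 10000 nM, which is a limit. No new step can be read from compound 4 to compound 3 or compound 1, because each pair rests on two limits: the limit of > 10000 nM in this assay, at which 3 of the 4 values shown sit.

The compounds shown leave open whether either methoxy in place of hydrogen or 4-bromophenoxy in place of chloro changes the potency at all.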